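A few compounds are considered here, and "the series" means these few. Any claim that something is new, unique, unknown or untested is made for them only; others in the source may bear on it.

Compound 1 `CC(C)CCN(CCC(C)C)S(=O)(=O)NC(=O)Nc1c(C(C)C)cccc1C(C)C` gives 420 nM in an assay on liver for inhibition of sterol O-acyltransferase 1 (Rattus norvegicus), using microsomes; on this read-out higher numbers stand for weaker inhibition and lower numbers for stronger inhibition. Compound 2 `CC(C)c1cccc(C(C)C)c1OC(=O)NS(=O)(=O)N1CCCCC1` returns only a limit in this assay, namely > 100000 nM, so it sits at the limit of > 100000 nM in this assay, at which 1 of the 2 values shown sits, and no number of its own is known. Compound 3 `CC(C)c1cccc(C(C)C)c1OC(=O)NS(=O)(=O)N1CCc2ccccc21` differs from compound 2 by 2,3-dihydro-1H-indol-1-yl in place of piperidin-1-yl on a sulfonyl sulfur. No measured step of this kind exists among these compounds, so the size of the move is uncertain; the expected shift from compound 2 to compound 3 in this assay of an at least 1.6-fold lower number from compound 2 to compound 3 (0.22 log units; that floor lies within the scatter) allows a modest gain or none beyond the scatter. Compound 3 is estimated at 60000 nM in this assay, with a range from 15000 nM to 200000 nM.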

Compound 3, half-maximal inhibitory concentration: 43000 nM
Compound 3: the middle estimate sits 1.4-fold (0.14 log units) above what was measured, within the range that was stated.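

In this assay, 2,3-dihydro-1H-indol-1-yl in place of piperidin-1-yl on a sulfonyl sulfur gives an at least 2.3-fold lower number from compound 2 to compound 3 (0.36 log units; beyond the scatter), so the group at this place does affect the read-out. Because compound 2 gives a limit and no number of its own, the full size of this step cannot be read: the limit of > 100000 nM in this assay, at which 1 of the 3 values shown sits.

The compounds shown leave open whether the six-membered aromatic ring of carbon only accounts for the step. They also do not show how morpholin-4-yl or diethylamino on the same sulfonyl sulfur would compare with compound 3.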